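From phenyl to 2-chlorophenyl in compound 3

The compounds below may be only part of what the source reports. "The series", "measured", "known", "first", "only" and "open" are said of these compounds alone.

Compound 1 `N#CCNC(=O)[C@@H]1C[C@@H](S(=O)(=O)c2ccccc2C(F)(F)F)C[C@H]1C(=O)N1CCOCC1` gives 2 nM
Compound 2 `CC(C)(C#N)NC(=O)[C@@H]1C[C@@H](S(=O)(=O)c2ccccc2)C[C@H]1C(=O)N1CCOCC1` gives 43 nM
Compound 3 `N#CCNC(=O)[C@@H]1CN(S(=O)(=O)c2ccccc2)C[C@H]1C(=O)N1CCOCC1` gives 4240 nM

In a functional assay on A20 cells (Mus musculus) for inhibition, with stated times of 1 h, 16 h and 24 h (a higher number here means a weaker inhibitor, a lower number a stronger inhibitor), compound 3 gives 4240 nM as the highest of the three numbers, and its gaps to compound 2 and to compound 1 both lie beyond the scatter. Compound 4 `N#CCNC(=O)[C@@H]1CN(S(=O)(=O)c2ccccc2Cl)C[C@H]1C(=O)N1CCOCC1` is compound 3 with one change, chloro in place of hydrogen on an aromatic carbon in all, which is chloro in place of hydrogen on an aromatic carbon, ortho to a large group. Going by the values given here, no measured pair isolates such a change. Compound 1 at 2 nM does carry trifluoromethyl on its aromatic ring, but it differs from compound 3 elsewhere too, so it supports only a cautious expectation. The expected change is a 5.3-fold lower number from compound 3 to compound 4 (0.72 log units; beyond the scatter) as a moderate move towards a lower number, beyond the scatter. For compound 4 the estimated value is 800 nM within an expected range of 150 nM to 3500 nM in this assay.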

Compound 4, half-maximal inhibitory concentration: 208 nM
Estimate against measurement, compound 4: 3.8-fold (0.59 log units) above; measured number inside the range.
By their numbers in this assay, from the lowest: compound 1; then compound 2; then compound 4; then compound 3.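

In this assay, going by these compounds alone, the phenyl to 2-chlorophenyl change gives a 20-fold lower number from compound 3 to compound 4 (1.31 log units; beyond the scatter), the first step in this set that isolates a single place. It shows that this aromatic carbon, ortho to a large group, is not indifferent to substitution: one chlorine atom in place of hydrogen, with the rest of the molecule unchanged, moves the number by a large margin, well beyond the scatter. No measurement offered here accounts for this gain.

The compounds shown leave open whether fluoro, bromo, methyl or methoxy at the same carbon would give a similar step. They also leave open whether chloro at another carbon of this aromatic ring would do the same, and whether the step carries over to other cores.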